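Methoxy in Place of Chloro on the Phenoxy Group

This account rests on a few compounds, and the source may have more. Where it says the series, first, only, none or still open, it means among the compounds named here.

Measured compounds:
compound 1, `Cc1cc(C)cc(Cc2ccc3c(NCCCNCc4ccco4)ccnc3c2)c1`, gives 6270 nM in an ADME assay on HepG2 cells (Homo sapiens) for cytotoxicity, read by luminescence, CellTiter-Glo and ATP content, with a stated time of 72 h; on this read-out lower numbers stand for an effect already at smaller amounts and higher numbers for an effect only at larger amounts of compound
compound 2, `COc1ccc(Oc2ccc3c(NCCCNCc4cc(F)ccc4OC)ccnc3c2)cc1`, gives 7000 nM
compound 3, `Clc1ccc(Oc2ccc3c(NCCCNCc4ccco4)ccnc3c2)cc1`, gives 7800 nM

Compound 3 stands highest of the three numbers in this assay, but its nearest neighbour, compound 2, and its furthest, compound 1, both lie within the scatter of it, so the three compounds are not told apart on this read-out. Compound 4, `COc1ccc(Oc2ccc3c(NCCCNCc4ccco4)ccnc3c2)cc1`, has not yet been measured. The change from compound 3 to compound 4 is methoxy in place of chloro on an aromatic carbon. For the measured compounds named here, only one measured step bears on this part of the molecule: the step of a 1.2-fold higher number from compound 1 to compound 3 (0.09 log units; within the scatter), which exchanged a much larger portion of the structure and still moved nothing beyond the scatter. Compound 2 already carries the 4-methoxyphenoxy group, and its number lies within the scatter of compound 3. Going by the values given here, with no measured step beyond the scatter, the step from compound 3 to compound 4 is expected to be a 1.1-fold lower number from compound 3 to compound 4 (0.05 log units; within the scatter), that is, no change beyond the scatter in this assay. Compound 4 is therefore estimated at 7000 nM, with a range from 3500 nM to 14000 nM.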

Compound 4, half-maximal effective concentration: 5300 nM
Estimate against measurement, compound 4: 1.3-fold (0.12 log units) above; the range from low to high includes it.
By their numbers in this assay, from the lowest: compounds 4, 1, 2 and 3 (each within the scatter of the next).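

In this assay the change from 4-chlorophenoxy to 4-methoxyphenoxy, on an aromatic carbon para to a large group, now has a direct reading: a 1.5-fold lower number from compound 3 to compound 4 (0.17 log units; within the scatter) shows that this exchange of chloro for methoxy, with its added hydrogen-bond acceptor, is not resolved on this read-out. The two other new steps also stay within the scatter: the exchange of 5-fluoro-2-methoxyphenyl for furan-2-yl gives a 1.3-fold lower number from compound 2 to compound 4 (0.12 log units; within the scatter) and the exchange of 3,5-dimethylbenzyl for 4-methoxyphenoxy gives a 1.2-fold lower number from compound 1 to compound 4 (0.07 log units; within the scatter) so all four compounds remain indistinguishable in this series. Nothing available accounts for the small differences that remain, and no measured property of either group bears on them.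

The compounds shown leave open whether any group at this position can move the number beyond the scatter, for example an amine or a carboxylic acid in place of methoxy. They also leave open whether a longer chain in place of methoxy would separate a compound from these four on this read-out.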